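Trading 4-Chlorophenyl for Vinyl on the Sulfur Chain

A few compounds are considered here, and "the series" means these few. Any claim that something is new, unique, unknown or untested is made for them only; others in the source may bear on it.

In a functional assay on MGC-803 cells (Homo sapiens) for inhibition, read by MTT assay, with a stated time of 72 h (a higher number here means a weaker inhibitor, a lower number a stronger inhibitor), compound 2 (`Cc1cc(Nc2cc(-c3ccccc3)[nH]n2)n2nc(SCc3ccc(Cl)cc3)nc2n1`) gives 3950 nM and compound 1 (`Cc1cc(Nc2cc(-c3ccccc3)[nH]n2)n2nc(SCCc3ccccc3)nc2n1`) gives 5620 nM so the two stand within the scatter of each other. Compound 3 (`C=CCSc1nc2nc(C)cc(Nc3cc(-c4ccccc4)[nH]n3)n2n1`) carries vinyl in place of 4-chlorophenyl on a saturated chain carbon bound to a sulfur. For the measured compounds named here, the one measured step that bears on this change is a 1.4-fold lower number from compound 1 to compound 2 (0.15 log units; within the scatter) and it lies within the scatter. Going by the values given here, compound 1 and compound 2 both keep an aromatic ring on this chain while compound 3 has none, so no measurement yet shows what losing it does. Among the compounds with values here, with only that small step as a guide, no step beyond the scatter is expected in this assay in either direction. For compound 3 the estimated value is 5000 nM with an expected range from 2000 nM to 13000 nM in a wide band. An estimated 1.3-fold higher number from compound 2 to compound 3 (0.10 log units; within the scatter) is what this expectation amounts to.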

Compound 3, half-maximal inhibitory concentration: 17200 nM
Compound 3: middle estimate off by 3.4-fold (0.54 log units), on the low side; the whole stated range lies below it.
By their numbers in this assay, from the lowest: compounds 2 and 1 (each within the scatter of the next); then compound 3.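

In this assay, for the compounds shown here, the group at the end of this sulfur chain does make a difference: replacing the aromatic ring with vinyl gives a 4.4-fold higher number from compound 2 to compound 3 (0.64 log units; beyond the scatter) and marks the first step here beyond the scatter. Set against the other ring-bearing compound, the same kind of change gives a 3.1-fold higher number from compound 1 to compound 3 (0.49 log units; beyond the scatter) and leaves compound 3, the only one of the three without a ring on the chain, as the weakest inhibitor. Nothing at hand explains this difference.

Vinyl differs from 4-chlorophenyl both in having no ring and in having fewer heavy atoms, so these compounds cannot separate the two changes. They also leave open how a saturated propyl chain, a small cyclopropyl ring or a chain ending in an amine would compare with allyl.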